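The compounds below may be only part of what the source reports. "The series", "measured", "known", "first", "only" and "open" are said of these compounds alone.

Three compounds share one core and have been examined in a physicochemical assay for metabolic stability, read by HPLC, with a stated time of 3 h, at pH 1, tested at 0.5 mM; a higher number here means that more of the compound is left, a lower number that less of the compound is left. Compound 1 `CC(=O)Oc1ccccc1C(=O)OCOC(=O)c1cccc(CO[N+](=O)[O-])n1` gives 84%. Compound 2 `CC(=O)Oc1ccccc1C(=O)OCOC(=O)c1cccc(OCCCO[N+](=O)[O-])c1` gives 99%. Compound 3 `CC(=O)Oc1ccccc1C(=O)OCOC(=O)c1ccc([S+]([O-])CCCO[N+](=O)[O-])cc1` gives 98%, the second highest of the three numbers; its nearest neighbour is compound 2, whose number lies within the scatter of it, while compound 1 lies beyond the scatter, with a lower number. Compound 4 `CC(=O)Oc1ccccc1C(=O)OCOC(=O)c1ccc(S(=O)(=O)CCCO[N+](=O)[O-])cc1` has not yet been measured in this assay. It differs from compound 3 in one place: a group of 10 heavy atoms (3 carbon, 1 nitrogen, 5 oxygen, 1 sulfur; no ring) in place of a group of 9 heavy atoms (3 carbon, 1 nitrogen, 4 oxygen, 1 sulfur; no ring), on an aromatic carbon. Since compounds 2 and 3 both stand near the top of the scale, compound 4 is expected to stay there too, with the step of a number 2 percentage points lower from compound 3 to compound 4 (within the scatter) expected to lie within the scatter. The estimate for compound 4 is 96%, between 88% and 100%.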

Compound 4, percent of the compound remaining: 98%
For compound 4 the middle estimate is 2 percentage points below the measured one, within the range that was stated.
By their numbers in this assay, from the lowest: compound 1; then compounds 3, 4 and 2 (each within the scatter of the next).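

Going by these compounds alone, compounds 3 and 4 form the first pair that differs in one place, and in this assay the (3-(nitrooxy)propyl)sulfonyl group, on an aromatic carbon para to a large group, gives no change at the digits printed from compound 3 to compound 4 (within the scatter). This position therefore tolerates this exchange at the sulfur-bearing chain without leaving the top of the scale. Nothing available explains this result. On these data alone, whether an amine, a carboxylic acid or a longer chain at this position would stay as high remains open.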